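Cytotoxicity Check for a Methylated Pyrazole Analogue

The source may hold more compounds than are shown below. What is called first, only, known or untested is meant among the compounds shown, and "the series" means these compounds.

compound 1 `O=c1nc(-c2ccccc2)c2cc(-c3cccnc3)ccc2[nH]1`: in an ADME assay on THP-1 cells (Homo sapiens) for cytotoxicity, read by MTT assay, with a stated time of 72 h (on this read-out lower numbers stand for an effect already at smaller amounts and higher numbers for an effect only at larger amounts of compound), compound 1 gives > 50000 nM, which is a limit of the assay.
compound 2 `O=c1nc(-c2ccccc2)c2cc(-c3cn[nH]c3)ccc2[nH]1`: in this assay compound 2 gives > 50000 nM, again a limit of the assay.

Compound 2 therefore stands at the limit of > 50000 nM in this assay, at which 2 of the 2 values shown sit, so the step that the two limits leave unreadable from compound 1 to compound 2 cannot be sized. Compound 3 `Cn1nccc1-c1ccc2[nH]c(=O)nc(-c3ccccc3)c2c1` differs from compound 2 by 1-methyl-1H-pyrazol-5-yl in place of 1H-pyrazol-4-yl on an aromatic carbon. For the measured compounds named here, no measured step shows this change in readable form, so nothing beyond the scatter is foreseen. Compound 3 is expected to remain at the limit, with an estimated value of 60000 nM and a range from 25000 nM to 200000 nM. This amounts to an expected step that the limit leaves unreadable from compound 2 to compound 3.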

Compound 3, half-maximal effective concentration: > 50000 nM
Compound 3 ended at the assay's limit; the forecaster's own chance of this, stated with the estimate: 85%; the middle value is on the limit's open side.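

No step can be read among compound 1, compound 2 and compound 3, because all three sit at the same limit: the limit of > 50000 nM in this assay, at which 3 of the 3 values shown sit.

The compounds shown leave open whether the swapped groups differ at all in cytotoxicity, since any effect would lie beyond that limit.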